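The compounds below may be only part of what the source reports. "The series", "measured", "known", "first", "only" and "open" are said of these compounds alone.

Measured compounds:
- compound 1 `O=C(O)c1cc(-c2cccc(COc3ccc4c(=O)n(C5CCC5)sc4c3)c2)ccc1Cl`: 83%
- compound 2 `O=C(O)c1ccc(-c2cccc(COc3ccc4c(c3)CN(C3CCCC3)C4=O)c2)c(Cl)c1`: 89.4%
- compound 3 `COc1ccc(-c2cccc(COc3ccc4c(c3)CN(C3CCCC3)C4=O)c2)cc1C(=O)O`: 78%

In an assay on HEK293 cells for positive allosteric modulation of metabotropic glutamate receptor 2 (Rattus norvegicus), read by thallium flux (on this read-out lower numbers stand for smaller maximal responses and higher numbers for larger maximal responses), compound 3 holds the lowest of the three numbers. Its nearest neighbour is compound 1, and that gap lies within the scatter of this assay, so the two cannot be told apart. The furthest is compound 2: the change a number 11.4 percentage points lower from compound 2 to compound 3 (beyond the scatter) is beyond the scatter, though modest in size.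

Compound 4 `COc1ccc(C(=O)O)cc1-c1cccc(COc2ccc3c(c2)CN(C2CCCC2)C3=O)c1` is related to compound 3 by 5-carboxy-2-methoxyphenyl in place of 3-carboxy-4-methoxyphenyl on an aromatic carbon. Within the data shown here, only one measured step exists in this set, the one from compound 2 to compound 3, and it exchanged an aryl group with different substituents rather than re-joining the same atoms, so it speaks only indirectly to the present change. That step was modest, and nothing here suggests that shuffling the carboxy and methoxy groups should produce a larger effect; with the whole series spanning a narrow band, the expected step of a number 1 percentage points higher from compound 3 to compound 4 (within the scatter) is none beyond the scatter. Compound 4 is therefore expected to give 79% in this assay, with a range from 66% to 92%.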

Compound 4, largest response reached (reported as percent of maximum), in percent of the reference or control that the assay uses: 79.2%
Compound 4: the middle estimate sits 0.2 percentage points below what was measured; low and high end bracket the measured number.
By their numbers in this assay, from the lowest: compounds 3, 4, 1 and 2 (each within the scatter of the next, the first and the last beyond it).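

Among these compounds, putting 5-carboxy-2-methoxyphenyl in place of 3-carboxy-4-methoxyphenyl, on an aromatic carbon meta to a large group, gives in this assay a number 1.2 percentage points higher from compound 3 to compound 4 (within the scatter) and so leaves the two arrangements indistinguishable, the first exchange at this place in which the atoms stay the same and only their joining changes. The step of a number 10.2 percentage points lower from compound 2 to compound 4 (beyond the scatter) stands with the earlier step of a number 11.4 percentage points lower from compound 2 to compound 3 (beyond the scatter), so at this place both methoxy-bearing aryl groups read beyond the scatter from the 4-carboxy-2-chlorophenyl group of compound 2, though both steps are modest. No evidence at hand accounts for this pattern.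

Compound 2 differs from compound 3 and compound 4 in more than one feature of the aryl group, and with no 4-carboxy-2-methoxyphenyl analogue among those shown, the gap cannot be assigned to the chlorine or to the place of the carboxylic acid. The compounds shown also leave open how a tetrazole or a primary amide in place of the carboxylic acid would read in this assay.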